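Carbamate to amide on the shared core: cytotoxicity notes

The compounds below may be only part of what the source reports. "The series", "measured", "known", "first", "only" and "open" are said of these compounds alone.

Within the data shown here, compound 1 `CC1CCCCC1N(CCCCCCN1C[C@H](O)[C@@H](O)[C@H](O)[C@H]1CO)C(=O)OC(C)(C)C` holds the only number in an ADME assay on MDBK cells (Bos taurus) for cytotoxicity, read by MTT assay; on this read-out lower numbers stand for higher toxicity in this test and higher numbers for lower toxicity in this test; in that test compound 1 gives 250000 nM. Compound 2 `OC[C@@H]1[C@@H](O)[C@H](O)[C@@H](O)CN1CCCCCCN(C1CCCCC1)C1CCCCC1` returns only a limit of the assay, > 500000 nM. Compound 2 therefore sits at the limit of > 500000 nM in this assay, at which 1 of the 2 values shown sits. Compound 3 `CC1CCCCC1N(CCCCCCN1C[C@H](O)[C@@H](O)[C@H](O)[C@H]1CO)C(=O)C(C)(C)C` is not yet measured; it differs from compound 1 by tert-butyl in place of tert-butoxy on a carbonyl carbon. Among the measured compounds shown here, no measured step of this kind exists, so no shift beyond the usual scatter is anticipated in either direction. The step is expected to be no change at the digits printed from compound 1 to compound 3 (within the scatter). Compound 3 is estimated at 250000 nM in this assay, with a range from 100000 nM to 600000 nM.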

Compound 3, half-maximal cytotoxic concentration: > 500000 nM
Compound 3: only a limit was reported (the forecaster's own chance of this, stated with the estimate: 30%); middle value at least 2.0-fold (0.30 log units) away from the limit.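

In this assay compound 3 gives > 500000 nM, which is a limit of the assay and not a number. Tert-butyl in place of tert-butoxy on a carbonyl carbon gives an at least 2.0-fold higher number from compound 1 to compound 3 (0.30 log units; that floor lies within the scatter), so this first reading at the position shows no drop in the number, while the true size of the step stays unknown. Readings in this series now gather at one ceiling: the limit of > 500000 nM in this assay, at which 2 of the 3 values shown sit.

Open, from the compounds shown here alone, is how far compound 3 actually lies from compound 1. Also open, going by these compounds, is whether an amine or a carboxylic acid on that carbonyl carbon would lower the number.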